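Working notes: vinyl to benzoyl, cytotoxicity unchanged so far

The compounds below may be only part of what the source reports. "The series", "measured", "known", "first", "only" and "open" are said of these compounds alone.

Three compounds have been run in an ADME assay on PC-3 cells (Homo sapiens) for cytotoxicity, read by WST assay, tested at 100 uM; a lower number here means less inhibition, a higher number more inhibition at the concentration tested (going by the name of the read-out). Compound 1 `O=C(Nc1cccc(Oc2nccc(C(F)(F)F)c2Cl)c1)C1CCCN(C(=O)c2cc(C(F)(F)F)cc(C(F)(F)F)c2)C1` gives 0% in this assay. Compound 3 `O=C(Nc1cccc(Oc2ccccc2)c1)C1CCCN(C(=O)c2cccc(-c3ccco3)c2)C1` gives 0% in this assay. Compound 2 `C=Cc1cccc(C(=O)N2CCCC(C(=O)Nc3ccc(Cl)cc3)C2)c1` gives 0% in this assay, level with compound 1 and compound 3 at the digits shown; its nearest neighbour is compound 1 and its furthest compound 3, both within the scatter. Going by the values given here, no pair of measured compounds differs in one place only, so no single-point step is available. Compound 4 `O=C(c1ccccc1)c1cccc(C(=O)N2CCCC(C(=O)Nc3ccc(Cl)cc3)C2)c1` is the next entry, differing from compound 2 by benzoyl in place of vinyl on an aromatic carbon. All measured values sit at the floor of the read-out, and the expected step is no change at the digits printed from compound 2 to compound 4 (within the scatter), none beyond the scatter. Compound 4 is estimated at 0% in this assay, within 0% to 12%.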

Compound 4, a percentage reported as inhibition, at one concentration (the size of the read-out at that concentration, not a potency): 0%
Beside the measured number, compound 4's estimate shows no gap at the digits printed; the range from low to high includes it.
By their numbers in this assay, from the lowest: compounds 1, 2, 3 and 4 (each within the scatter of the next).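

In this assay, going by these compounds alone, the first single-place step reads no change at the digits printed from compound 2 to compound 4 (within the scatter) with benzoyl in place of vinyl on an aromatic carbon, meta to a large group. This position therefore takes a six-membered aromatic ring of carbon only and a hydrogen-bond acceptor with compound 4 at 0%. Nothing at hand bears on this result.

From the compounds shown here alone, whether an amine or a carboxylic acid on that aromatic carbon would give a read-out above the floor stays open. Going by these compounds, a step between two compounds off the floor is also still missing, so how far this position matters in this assay remains unknown.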